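This account rests on a few compounds, and the source may have more. Where it says the series, first, only, none or still open, it means among the compounds named here.

Of the compounds shown here, three sharing one core have been measured in a functional assay on U-87MG ATCC cells for antiproliferative activity against U-87 MG (Homo sapiens), read by MTT assay, with a stated time of 48 h, tested at 5 uM; on this read-out lower numbers stand for a stronger effect and higher numbers for a weaker effect at the one concentration tested. Compound 1, `Cc1nc(-c2ccc(Cl)cc2)sc1C(=O)CSc1nc(-c2ccccc2)c(C#N)c(=O)[nH]1`, gives 88.9%. Compound 2, `COc1ccc(-c2nc(SCC(=O)c3sc(-c4ccccc4)nc3C)[nH]c(=O)c2C#N)cc1`, gives 97.3%, and compound 3, `COc1cccc(-c2nc(SCC(=O)c3sc(-c4ccccc4)nc3C)[nH]c(=O)c2C#N)c1`, gives 99%. Compound 1 thus has a number lower than compound 3, beyond the scatter, while compound 2 lies within the scatter of compound 1. Among the measured compounds shown here, the one measured step, a number 1.7 percentage points higher from compound 2 to compound 3 (within the scatter), moved the methoxy group around the phenyl on the core and changed nothing beyond the scatter.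

Compound 4, `Cc1nc(-c2ccc(Cl)cc2)sc1C(=O)CSc1nc(-c2cccc(Cl)c2)c(C#N)c(=O)[nH]1`, differs from compound 1 by chloro in place of hydrogen on an aromatic carbon. Read one bond further out, this is phenyl to 3-chlorophenyl on that same phenyl. For the measured compounds named here, no measured step adds a chloro group at this position, so the only guide is that shifting a group around this ring, as from compound 2 to compound 3, left the read-out where it was. The expected step, a number 2.9 percentage points lower from compound 1 to compound 4 (within the scatter), is therefore small. Compound 4 is estimated at 86%, between 68% and 100%.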

Compound 4, a percentage reported as activity, at one concentration (the size of the read-out at that concentration, not a potency): 80.2%
Compound 4: middle estimate off by 5.8 percentage points, on the high side, within the range that was stated.
By their numbers in this assay, from the lowest: compounds 4, 1, 2 and 3 (each within the scatter of the next, the first and the last beyond it).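

In this assay, chloro in place of hydrogen on the phenyl of the core, meta to a large group, gives a number 8.7 percentage points lower from compound 1 to compound 4 (within the scatter). Among the compounds shown here, compound 2 and compound 3 showed only that moving a methoxy group around this ring leaves the read-out within the scatter, whereas this step shows that adding a single chlorine atom to the unsubstituted phenyl of compound 1 also stays within it, so this one position tolerates the new atom without a clear loss or gain in effect. No other measurement bears on why this read-out behaves as it does.

An amine, a carboxylic acid or a longer chain at this position could still shift the read-out beyond the scatter. With a single concentration, the shown compounds also leave open how potency differs across this series.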